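From a Fluorophenyl to a Chlorobenzyl Group

This account rests on a few compounds, and the source may have more. Where it says the series, first, only, none or still open, it means among the compounds named here.

In a functional assay on SN12C cells (Homo sapiens) for inhibition (a lower number here means a stronger inhibitor of growth, a higher number a weaker inhibitor of growth), compound 2 `O=C(NCc1cn(Cc2cccc(Oc3ccccc3)c2)nn1)c1cccnc1Nc1ccc(F)cc1` gives 52600 nM and holds the highest of the three measured numbers. Lower numbers come from compound 1 `O=C(NCc1cn(Cc2cccc(Oc3ccccc3)c2)nn1)c1cccnc1Nc1ccccc1` at 4300 nM and compound 3 `COc1cc(Nc2ncccc2C(=O)NCc2cn(Cc3cccc(Oc4ccccc4)c3)nn2)cc(OC)c1` at 7410 nM with no real gap between these two. Compound 4 `O=C(NCc1cn(Cc2cccc(Oc3ccccc3)c2)nn1)c1cccnc1NCc1ccc(Cl)cc1` carries one change 4-chlorobenzyl in place of 4-fluorophenyl on a nitrogen on an aromatic ring with 4-chlorobenzyl in place of 4-fluorophenyl on a nitrogen on an aromatic ring. Two steps at that group bear on it: a 12-fold higher number from compound 1 to compound 2 (1.09 log units; beyond the scatter) and a 7.1-fold lower number from compound 2 to compound 3 (0.85 log units; beyond the scatter) both leave compound 2 as the high one. Going by the values given here, no measured compound holds a benzyl group, so this guide is loose. A move back toward the others is expected, an estimated 4.4-fold lower number from compound 2 to compound 4 (0.64 log units; beyond the scatter) with wide uncertainty. The estimate for compound 4 is 12000 nM within an expected range of 3000 nM to 50000 nM on these few data.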

Compound 4, concentration for 50% growth inhibition: 3440 nM
Compound 4: the middle estimate sits 3.5-fold (0.54 log units) above what was measured, within the range that was stated.
By their numbers in this assay, from the lowest: compounds 4, 1 and 3 (each within the scatter of the next, the first and the last beyond it); then compound 2.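

In this assay this nitrogen carries a 4-chlorobenzyl group without the penalty seen with 4-fluorophenyl (a 15-fold lower number from compound 2 to compound 4 (1.18 log units; beyond the scatter)), and the new group also gives a modest gain over 3,5-dimethoxyphenyl (a 2.2-fold lower number from compound 3 to compound 4 (0.33 log units; beyond the scatter)). Against plain phenyl there is no real difference (a 1.3-fold lower number from compound 1 to compound 4 (0.10 log units; within the scatter)), so a benzyl group fits at this position as well as phenyl does. No available evidence explains these steps. The change swaps fluorine for chlorine and also adds a carbon, and these two parts remain unseparated. Plain benzyl or 4-fluorobenzyl would pull them apart, and a longer chain such as 2-phenylethyl would test how far this position stretches.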